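Chloro on the Fluorophenyl Ring of Compound 1

This account rests on a few compounds, and the source may have more. Where it says the series, first, only, none or still open, it means among the compounds named here.

Of the compounds shown here, three have been measured in a functional assay on DU-145 cells (Homo sapiens) for inhibition, read by trypan blue exclusion, with a stated time of 96 h; on this read-out higher numbers stand for weaker inhibition of growth and lower numbers for stronger inhibition of growth. Compound 1 `O=C(/C(=C\c1ccc(F)cc1)S(=O)(=O)c1ccc(Br)cc1)c1ccc(Br)cc1` gives 4000 nM, the second highest of the three numbers. Compound 2 `COc1cc(OC)c(/C=C(/SCc2ccc(F)cc2)C(=O)c2ccc(Cl)cc2)c(OC)c1` gives 10000 nM, and compound 3 `COc1ccccc1/C=C(/SCc1ccc(Cl)cc1)C(=O)c1ccc(Br)cc1` gives 1000 nM. The number for compound 1 lies nearer to compound 2 than to compound 3, and both gaps lie beyond the scatter. Compounds 2 and 3 differ from compound 1 at several places at once, so no single change can be read from the measured pairs.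

Compound 4 `O=C(/C(=C\c1ccc(F)cc1Cl)S(=O)(=O)c1ccc(Br)cc1)c1ccc(Br)cc1` is not yet measured. It differs from compound 1 in one place: chloro in place of hydrogen on an aromatic carbon. Among the compounds with values here, no pair of measured compounds shares this difference, so nothing measured here sets the size of the step. The step is expected to be small, as a 1.3-fold lower number from compound 1 to compound 4 (0.12 log units; within the scatter), at or near the usual scatter, in the direction of slightly stronger inhibition of growth. Compound 4 is therefore estimated at 3000 nM, with a range from 1000 nM to 10000 nM.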

Compound 4, concentration for 50% growth inhibition: 50000 nM
Estimate against measurement, compound 4: 17-fold (1.22 log units) below, and the stated range ends below it.
By their numbers in this assay, from the lowest: compound 3; then compound 1; then compound 2; then compound 4.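

In this assay chloro in place of hydrogen on an aromatic carbon, ortho to a large group and meta to a fluoro group, is far from a neutral change: 4-fluorophenyl to 2-chloro-4-fluorophenyl gives a 13-fold higher number from compound 1 to compound 4 (1.10 log units; beyond the scatter) toward weaker inhibition of growth. Within the data shown here, this is the first single-place step, and it marks this ring carbon as sensitive to substitution on the core of compound 1, though the reading rests on this one pair. Nothing at hand gives a reason for the loss.

The compounds shown leave open whether the loss is specific to chloro or follows from any group on this carbon; a methyl group or an amine there would separate the two. Also open, going by these compounds, is whether the same change costs as much on the sulfide compounds, such as compound 3.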